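This account rests on a few compounds, and the source may have more. Where it says the series, first, only, none or still open, it means among the compounds named here.

Series notes in this assay. The read-out is a functional assay on CHO cells for agonist activity at Free fatty acid receptor 1 (Homo sapiens), read by FLIPR, tested at 100 nM; on this read-out lower numbers stand for a weaker effect and higher numbers for a stronger effect at the one concentration tested. Compound 1 `Cc1cc(OCCCS(C)(=O)=O)cc(C)c1-c1cccc(COc2ccc(OCC(=O)O)c(F)c2)c1` gives 54.9% in this assay. Within the data shown here, compound 2 `O=C(O)COc1ccc(NC(=O)C(=O)Nc2ccccc2)cc1F` gives 9.78% in this assay; this is the lowest of the two numbers so far, and compound 1 stands higher by a margin beyond the scatter. Among the measured compounds shown here, no one-place step between these two measured compounds is available, so the two values are only set side by side and nothing further is read from the pair.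

Compound 3 `Cc1ccc(NC(=O)C(=O)Nc2ccc(OCC(=O)O)c(F)c2)cc1` is the next candidate for this assay. It is built from compound 2 by one change: methyl in place of hydrogen on an aromatic carbon The entering group sits on an aromatic carbon of a six-membered aromatic ring of carbon only, para to a large group.

With no measured step of this kind in the set, the expectation rests on the value of compound 2 alone, which is low at 9.78%. The step from compound 2 to compound 3 is expected to be small, a number 4.2 percentage points higher from compound 2 to compound 3 (within the scatter), with no direction beyond the scatter. Compound 3 is thus estimated at 14% in this assay. Compound 3 is expected to fall between 3% and 30%.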

Compound 3, a percentage reported as activity, at one concentration (the size of the read-out at that concentration, not a potency): 11.4%
Estimate against measurement, compound 3: 2.6 percentage points above; the measured number falls inside the stated range.
By their numbers in this assay, from the lowest: compounds 2 and 3 (each within the scatter of the next); then compound 1.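

In this assay, the series now has its first one-place step: methyl in place of hydrogen on an aromatic carbon, para to a large group, reads as a number 1.6 percentage points higher from compound 2 to compound 3 (within the scatter). At this position, the change from phenyl to 4-methylphenyl therefore gives two compounds that cannot be told apart on this read-out at the one concentration tested, with compound 3 at 11.4%. No supporting measurement bears on this step, and the result stays an observation without an explanation.

The compounds shown leave open whether another group at this same place, such as methoxy, chlorine, trifluoromethyl or a longer chain such as ethyl, would give a step beyond the scatter. Among these compounds, also open is whether a methyl on the other carbons of this ring would read the same way, as this single step describes only the one place and the one entering group.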